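This account rests on a few compounds, and the source may have more. Where it says the series, first, only, none or still open, it means among the compounds named here.

Measured compounds in a functional assay on CCRF-CEM cells for antagonist activity at C-X-C chemokine receptor type 4 (Homo sapiens), read by calcium flux, with stated times of 25 min and 90 s; on this read-out lower numbers stand for stronger inhibition and higher numbers for weaker inhibition:
compound 1 `CN(C)[C@H]1CCN(c2cccc3c2C[C@H](CN(C)[C@H]2CCCc4cccnc42)NC3)C1` gives 10.9 nM
compound 2 `CN(C)[C@@H]1CCN(c2cccc3c2C[C@H](CN(C)[C@H]2CCCc4cccnc42)NC3)C1` gives 10.4 nM
compound 3 `CN1CC[C@H]2CN(c3cccc4c3C[C@H](CN(C)[C@H]3CCCc5cccnc53)NC4)C[C@H]21` gives 11.4 nM

Compound 3 carries the highest of the three numbers in this assay, but its gaps to compound 1 and compound 2 are both within the scatter, so no order among the three can be read. Compound 4 `CN(C[C@H]1Cc2c(cccc2N2C[C@H]3CCN(C)[C@H]3C2)CN1)[C@H]1CCCc2cccnc21` has not been measured. It differs from compound 3 only in configuration: the two compounds have the same atoms and bonds and differ only in configuration as drawn: 2 of 4 stereo elements differ; a stereocentre at a saturated ring carbon is drawn S in compound 3 and R in compound 4; a stereocentre at a saturated ring carbon is drawn S in compound 3 and R in compound 4. Within the data shown here, the one measured step that bears on such a change is a 1.0-fold lower number from compound 1 to compound 2 (0.02 log units; within the scatter), an inversion at a single saturated ring carbon that left the number unchanged; this rests on (the fact that compounds 1 and 2 differ only in the configuration as drawn). Among the measured compounds shown here, no measured step covers an inversion at two centres at once, and the bicyclic amine of compound 3 and compound 4 has not itself been varied in configuration, so the range is kept wider. On that basis compound 4 is expected to show a 1.1-fold higher number from compound 3 to compound 4 (0.06 log units; within the scatter), no step beyond the scatter. For compound 4 the estimate in this assay is 13 nM, with a range from 5 nM to 40 nM.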

Compound 4, half-maximal inhibitory concentration: 18.7 nM
Estimate against measurement, compound 4: 1.4-fold (0.16 log units) below, within the range that was stated.
By their numbers in this assay, from the lowest: compounds 2, 1, 3 and 4 (each within the scatter of the next).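

In this assay, inverting both saturated ring carbons of the group with 2 five-membered non-aromatic rings gives a 1.6-fold higher number from compound 3 to compound 4 (0.21 log units; within the scatter), so this double inversion stays within the scatter, as the single inversion did in the earlier pair. The configuration of this group can therefore be changed at two centres together without a readable shift in this assay, and this step is read as one of configuration alone: the fact that compounds 3 and 4 differ only in the configuration as drawn. With the inverted group in place of the group with one five-membered non-aromatic ring, the comparisons give a 1.8-fold higher number from compound 2 to compound 4 (0.25 log units; within the scatter) and a 1.7-fold higher number from compound 1 to compound 4 (0.23 log units; within the scatter), both also within the scatter.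

Still open, from the compounds shown here alone, is what inverting only one of the two centres would give. Going by these compounds, it is also open whether a carboxylic acid or a morpholine on this aromatic carbon would stay within the scatter.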